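Ethyl on the amide nitrogen: from compound 3 to compound 4

The compounds below may be only part of what the source reports. "The series", "measured", "known", "first", "only" and "open" are said of these compounds alone.

Compound 1: `CCCC(=O)C1=Cc2ccc(OC)cc2OC1c1cc(OC)c(OC)c(OC)c1`, 11700 nM
Compound 2: `CCOC(=O)C1=Cc2ccc(OC)cc2OC1c1cc(OC)c(OC)c(OC)c1`, 25000 nM
Compound 3: `COc1ccc2c(c1)OC(c1cc(OC)c(OC)c(OC)c1)C(C(N)=O)=C2`, > 50000 nM (a limit of the assay, not a number)

The three measured compounds share one core and differ only in the group on the carbonyl carbon. In a functional assay for inhibition of nuclear factor NF-kappa-B complex (Homo sapiens) (on this read-out lower numbers stand for stronger inhibition and higher numbers for weaker inhibition), compound 1 gives 11700 nM. Compound 2 gives 25000 nM, a step of a 2.1-fold higher number from compound 1 to compound 2 (0.33 log units; beyond the scatter). For compound 3 the assay reports only a limit, > 50000 nM, so compound 3 sits at the limit of > 50000 nM in this assay, at which 1 of the 3 values shown sits. The step of an at least 4.2-fold higher number from compound 1 to compound 3 (0.63 log units; beyond the scatter) is beyond the scatter, whereas the step of an at least 2.0-fold higher number from compound 2 to compound 3 (0.30 log units; that floor lies within the scatter) has a floor that lies within it. For the measured compounds named here, compound 3 is therefore the one compound of the three for which no number is known.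

Compound 4, `CCNC(=O)C1=Cc2ccc(OC)cc2OC1c1cc(OC)c(OC)c(OC)c1`, has not yet been measured in this assay. It differs from compound 3 by ethyl in place of hydrogen on an amide-type nitrogen, that is, carbamoyl becomes ethylcarbamoyl. Going by the values given here, none of the measured steps alters an amide-type nitrogen; all three exchange the whole group on the carbonyl carbon, and the two steps that end at compound 3 point upward into the limit. Among the compounds with values here, no measured step tells how an ethyl on the amide nitrogen moves the number, so the expectation for compound 4 stays near compound 3. Compound 4 is expected at 40000 nM, within 15000 nM to 100000 nM, a step of an at least 1.2-fold lower number from compound 3 to compound 4 (0.09 log units; that floor lies within the scatter) that is expected to stay close to the scatter, with a fair chance that only a limit is reported again.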

Compound 4, half-maximal inhibitory concentration: > 50000 nM
Compound 4: a limit, no number; the forecaster's own chance of this, stated with the estimate: 50%; middle value at least 1.2-fold (0.09 log units) away from the limit.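

In this assay, compound 4, like compound 3, is reported only as a limit, so the step made by ethyl in place of hydrogen on an amide-type nitrogen cannot be read: the limit of > 50000 nM in this assay, at which 2 of the 4 values shown sit.

What is new is that an amide with a substituent on its nitrogen can now be set against the other groups on the carbonyl carbon. Ethylamino in place of propyl gives an at least 4.2-fold higher number from compound 1 to compound 4 (0.63 log units; beyond the scatter), and ethylamino in place of ethoxy gives an at least 2.0-fold higher number from compound 2 to compound 4 (0.30 log units; that floor lies within the scatter). Adding ethyl to the amide nitrogen therefore yields no measurable number in this assay, and compound 1 stands clearly apart from compound 4, whereas the separation of compound 2 from compound 4 has a floor that remains within the scatter.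

On these data alone, how far compound 3 and compound 4 lie beyond their limits, and whether ethyl moves the value at all, remains open. Also open, as far as these compounds go, is whether a longer chain such as butyl on the amide nitrogen, or a carboxylic acid in place of the amide, would give a number in this assay.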